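Urea-linked anilines on the shared core: step to compound 4

The source may report more compounds than this note shows. Statements on the series, on what has been measured and on what is new or still open speak of the compounds shown alone.

Three compounds of the series have numbers in a functional assay on MDA-MB-435 cells (Homo sapiens) for inhibition, read by sulforhodamine B assay, with a stated time of 48 h, tested at 100 uM; a lower number here means a stronger effect, a higher number a weaker effect of the compound at the concentration tested. Compound 1 `COc1cc(Cl)cc(-c2nn(-c3cccc(NC(=O)Nc4ccc(Cl)c(C(F)(F)F)c4)c3)cc2-c2ccncc2)c1` gives -40%. Compound 2 `COc1cc(Cl)cc(-c2nn(-c3cccc(NC(=O)Nc4cc(C(F)(F)F)cc(C(F)(F)F)c4)c3)cc2-c2ccncc2)c1` gives -81%. Compound 3 `COc1cc(Cl)cc(-c2nn(-c3cccc(NC(=O)Nc4ccc(Cl)c(Cl)c4)c3)cc2-c2ccncc2)c1` gives -33%, the highest of the three numbers: compound 1 sits nearest to it, seven points lower and within the scatter, while compound 2 sits furthest, lower by more than the scatter.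

Compound 4 `COc1cc(Cl)cc(-c2nn(-c3cccc(NC(=O)Nc4cccc(C(F)(F)F)c4)c3)cc2-c2ccncc2)c1` is not yet measured. It differs from compound 3 by 3-(trifluoromethyl)phenyl in place of 3,4-dichlorophenyl on an amide-type nitrogen.

Among the compounds with values here, one measured step bears on this change. The step of a number 7 percentage points higher from compound 1 to compound 3 (within the scatter) shows that chloro in place of trifluoromethyl on an aromatic carbon moved the number by less than the scatter. Within the data shown here, compound 4 returns to a single trifluoromethyl and drops the second chloro, so by that step no shift beyond the scatter is expected; the value of compound 2, -81%, carries two trifluoromethyl groups and is not a direct guide, and the pair of compounds 2 and 4 has no measured step.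

Compound 4 is therefore expected to land close to compound 3, with an estimated step of a number 3 percentage points higher from compound 3 to compound 4 (within the scatter), leaving compound 4 at an estimated -30% within -60% to 0%.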

Compound 4, a percentage reported as activity, at one concentration (the size of the read-out at that concentration, not a potency): -74%
Compound 4: middle estimate off by 44 percentage points, on the high side, outside the stated range (below it).
By their numbers in this assay, from the lowest: compounds 2 and 4 (each within the scatter of the next); then compounds 1 and 3 (each within the scatter of the next).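

Within the data shown here, on the amide-type nitrogen, this assay separates aryl groups more sharply than the earlier compounds showed: 3-(trifluoromethyl)phenyl in place of 3,4-dichlorophenyl gives a number 41 percentage points lower from compound 3 to compound 4 (beyond the scatter), whereas the earlier exchange of trifluoromethyl for chloro gave only a number 7 percentage points higher from compound 1 to compound 3 (within the scatter). The other two comparisons point to the chloro shared by compound 1 and compound 3: hydrogen in its place gives a number 34 percentage points lower from compound 1 to compound 4 (beyond the scatter), while hydrogen in place of the second trifluoromethyl gives a number 7 percentage points higher from compound 2 to compound 4 (within the scatter), so all four compounds fall into two groups, those with this chloro and those without it, with no exception among them. No supporting measurement bears on why this chloro has so large an effect on the read-out.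

From the compounds shown here alone, it remains open whether a methyl, a methoxy or a nitrile on that ring carbon would leave the read-out with compound 4 and compound 2 or return it to compound 1 and compound 3. Going by these compounds, it also remains open whether the separation between these two groups persists at lower concentrations, since a single concentration gives no potency.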